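The compounds below may be only part of what the source reports. "The series", "measured", "known", "first", "only" and "open" are said of these compounds alone.

In a functional assay on FM3A cells (Mus musculus) for inhibition (a higher number here means a weaker inhibitor, a lower number a stronger inhibitor), compound 1 `O=C1O/C(=C\Cn2cc(I)c(=O)[nH]c2=O)C(OCc2ccccc2)=C1OCc1ccccc1` gives 22600 nM. Compound 2 `O=C1O/C(=C\Cn2ccc(=O)[nH]c2=O)C(OCc2ccccc2)=C1OCc1ccccc1`, which carries hydrogen in place of iodo on an aromatic carbon, gives 17700 nM. Going by the values given here, these are the only two exact numbers so far. The step between them is a 1.3-fold lower number from compound 1 to compound 2 (0.11 log units; within the scatter), so the two compounds stand level and compound 1 has no measurable edge over compound 2.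

Compound 3 `O=C1O/C(=C\Cn2cnc3c(-n4cccc4)ncnc32)C(OCc2ccccc2)=C1OCc1ccccc1` reports only a limit of the assay, > 200000 nM.

The next compound to consider is compound 4 `O=C1O/C(=C\Cn2cc(Br)c(=O)[nH]c2=O)C(OCc2ccccc2)=C1OCc1ccccc1`, which has bromo in place of iodo on an aromatic carbon of a six-membered aromatic ring with 2 nitrogen: bromo in place of iodo on an aromatic carbon. The rest of the structure of compound 1 stays the same.

Among the compounds with values here, only one measured step bears on this change, the replacement of iodo by hydrogen at the same place. That step, a 1.3-fold lower number from compound 1 to compound 2 (0.11 log units; within the scatter), stays within the scatter. Replacing iodo with bromo is therefore expected to leave the number in this assay about where it is, with no step beyond the scatter in either direction.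

The expected change is small, an estimated 1.1-fold lower number from compound 1 to compound 4 (0.05 log units; within the scatter).

For compound 4 the estimate is 20000 nM, with an expected range from 9500 nM to 42000 nM.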

Compound 4, half-maximal inhibitory concentration: 17100 nM
Compound 4: middle estimate off by 1.2-fold (0.07 log units), on the high side; the range from low to high includes it.
By their numbers in this assay, from the lowest: compounds 4, 2 and 1 (each within the scatter of the next). At a limit, above all of these: compound 3.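

In this assay, swapping iodo for bromo on this aromatic carbon, two atoms from the ring nitrogen, gives a 1.3-fold lower number from compound 1 to compound 4 (0.12 log units; within the scatter), and putting bromo in place of hydrogen gives a 1.0-fold lower number from compound 2 to compound 4 (0.01 log units; within the scatter). Until now this position rested on a single pair, iodo against hydrogen, but it now has three substituents that cannot be told apart: with iodo, bromo or hydrogen on this carbon, and the rest of the structure unchanged, compounds 1, 2 and 4 stand level, so in this small set the halogen and its size of atom make no readable difference to the number, and even having no halogen at all does not. Nothing measured here offers a reason for this flat result.

Going by these compounds, all three groups tested at this position are a single atom, so it stays open whether a group of another kind on the same carbon, such as an amine, a carboxylic acid or a longer chain, would move the number beyond the scatter. On these data alone, whether chloro or fluoro would also stand level with compounds 1, 2 and 4 remains open too.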